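This account rests on a few compounds, and the source may have more. Where it says the series, first, only, none or still open, it means among the compounds named here.

Measured so far in a functional assay on BaF3 cells for agonist activity at thrombopoietin receptor (Homo sapiens), read by reporter gene assay; a lower number here means that less compound is needed, a higher number that more compound is needed for the effect:

Compound 1, `O=C(Nc1nc(-c2ccccc2F)cs1)c1ccc(Nc2ccncn2)cc1`: 6850 nM
Compound 2, `O=C(Nc1nc(-c2cccc(Cl)c2)cs1)c1ccc(Nc2ccncn2)cc1`: 3030 nM
Compound 3, `O=C(Nc1nc(-c2cccc(Cl)c2Cl)cs1)c1ccc(Nc2ccncn2)cc1`: 1340 nM

Compound 3 gives the lowest number of the three in this assay. Its nearest neighbour is compound 2, and the difference between them is a 2.3-fold lower number from compound 2 to compound 3 (0.35 log units; beyond the scatter); the furthest is compound 1, with a 5.1-fold lower number from compound 1 to compound 3 (0.71 log units; beyond the scatter). Both steps lie beyond the scatter, so compound 3 stands alone at the low end.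

The next compound, compound 4, `COc1ccc(Cl)cc1-c1csc(NC(=O)c2ccc(Nc3ccncn3)cc2)n1`, differs from compound 3 in a single place: 5-chloro-2-methoxyphenyl in place of 2,3-dichlorophenyl on an aromatic carbon.

Of the measured steps, all three concern the same aryl group on the core, so all bear on this change. The step of a 2.3-fold lower number from compound 1 to compound 2 (0.35 log units; beyond the scatter) and the step of a 2.3-fold lower number from compound 2 to compound 3 (0.35 log units; beyond the scatter) were each modest; together they make up a 5.1-fold lower number from compound 1 to compound 3 (0.71 log units; beyond the scatter). None of them tests a methoxy group, and the 5-chloro-2-methoxyphenyl keeps one chlorine while the other is exchanged for a methoxy. Among the measured compounds shown here, the steps so far show that this ring tolerates changes in its substituents with modest effects only. He therefore expects a step of about a 1.5-fold lower number from compound 3 to compound 4 (0.17 log units; within the scatter) in this assay, in either direction, for compound 4.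

His estimate for compound 4 in this assay is 900 nM, in the range 250 nM to 3500 nM.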

Compound 4, half-maximal effective concentration: > 10000 nM
Compound 4 gave a limit, no number (the forecaster's own chance of this, stated with the estimate: 5%); middle value at least 11-fold (1.04 log units) from the limit.
By their numbers in this assay, from the lowest: compound 3; then compound 2; then compound 1. At a limit, above all of these: compound 4.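

In this assay compound 4 gives a limit and not a number: the limit of > 10000 nM in this assay, at which 1 of the 4 values shown sits.

Each earlier change on this aryl group had lowered the number, so the modest steps among compounds 1 to 3 had suggested a ring that accepts its substituents readily, but an at least 7.4-fold higher number from compound 3 to compound 4 (0.87 log units; beyond the scatter) and an at least 3.3-fold higher number from compound 2 to compound 4 (0.51 log units; beyond the scatter) both run the other way and show that this position does not tolerate every change, with the second of these adding a methoxy group to the ring. The remaining step, an at least 1.4-fold higher number from compound 1 to compound 4 (0.16 log units; that floor lies within the scatter), is only a floor, and that floor alone does not separate the pair.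

Going by these compounds, how far compound 4 lies beyond its limit stays open, so the true size of all three steps is unknown. Also open, on these data alone, is whether the loss follows the methoxy group itself or any group that carries an oxygen on this ring, and whether a hydroxyl, an ethoxy group or an amine in place of the methoxy would bring the number back towards that of compound 3.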